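Chloro for fluoro on the way to compound 3

The source may report more compounds than this note shows. Statements on the series, on what has been measured and on what is new or still open speak of the compounds shown alone.

For the measured compounds named here, in a functional assay on K562 cells (Homo sapiens) for cytotoxicity, read by MTT assay, with a stated time of 24 h (on this read-out lower numbers stand for stronger inhibition and higher numbers for weaker inhibition), compound 1 (`COc1cc(/C=C2\CN(C)C/C(=C\c3ccccc3F)C2=O)cc(OC)c1`) gives 6320 nM and compound 2 (`COc1cc(/C=C2\CN(C)C/C(=C\c3ccc(F)cc3)C2=O)cc(OC)c1`) gives 11300 nM as the second of the two numbers, so compound 2 stands within the scatter of its only neighbour. Compound 3 (`COc1cc(/C=C2\CN(C)C/C(=C\c3ccc(Cl)cc3)C2=O)cc(OC)c1`) carries chloro in place of fluoro on an aromatic carbon, para to a large group (chloro in place of fluoro on an aromatic carbon). Going by the values given here, the one measured step (a 1.8-fold higher number from compound 1 to compound 2 (0.25 log units; within the scatter)) involves no chloro group and bears only loosely, so no step beyond the scatter is expected in this assay here. The expected change is a 1.3-fold lower number from compound 2 to compound 3 (0.10 log units; within the scatter) and nothing larger. For compound 3 the estimated value is 9000 nM with an expected range from 3500 nM to 23000 nM in this test.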

Compound 3, half-maximal inhibitory concentration: 13300 nM
For compound 3 the middle estimate is 1.5-fold (0.17 log units) below the measured one, within the range that was stated.
By their numbers in this assay, from the lowest: compounds 1, 2 and 3 (each within the scatter of the next, the first and the last beyond it).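

In this assay, chloro in place of fluoro on an aromatic carbon, para to a large group, leaves the number within the scatter (a 1.2-fold higher number from compound 2 to compound 3 (0.07 log units; within the scatter)), so the two halogens are not told apart at this place. For the compounds shown here, the step from 2-fluorophenyl to 4-chlorophenyl (a 2.1-fold higher number from compound 1 to compound 3 (0.32 log units; beyond the scatter)) is the first beyond the scatter, though it is modest and changes both the halogen and where it sits. Nothing available explains either step.

The compounds shown leave open how 2-chlorophenyl would compare with 2-fluorophenyl. They also leave open what an amine or a carboxylic acid on that aromatic carbon would do.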